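Adding a methoxy to the fused ring of compound 1

The source may hold more compounds than are shown below. What is called first, only, known or untested is meant among the compounds shown, and "the series" means these compounds.

The measured compounds:
compound 1, `COc1cc(-c2ccc(C)n2-c2ccc(-c3nc4ccccc4s3)cc2)cc(OC)c1OC`: 3450 nM
compound 2, `Cc1ccc(-c2ccc([N+](=O)[O-])cc2)n1-c1ccc(-c2nc3ccc(F)cc3s2)cc1`: 1670 nM
compound 3, `COc1ccc2nc(-c3ccc(-n4c(C)ccc4-c4ccc(F)cc4)cc3)sc2c1`: 4060 nM

All three were tested in a functional assay on MDA-MB-231 cells (Homo sapiens) for cytotoxicity, read by sulforhodamine B assay, with a stated time of 48 h; on this read-out lower numbers stand for stronger inhibition of growth and higher numbers for weaker inhibition of growth. Compound 1 sits second highest among the three numbers. Compound 3 is its closest neighbour, and the gap between the two lies within the usual scatter, so no order between them can be claimed. Compound 2 gives the lowest number of the set, and its distance from compound 1 lies beyond the scatter.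

The unmeasured compound 4, `COc1ccc2nc(-c3ccc(-n4c(C)ccc4-c4cc(OC)c(OC)c(OC)c4)cc3)sc2c1`, differs from compound 1 in one place: methoxy in place of hydrogen on an aromatic carbon. The shared core, including the trimethoxyphenyl substituent, is kept unchanged.

Going by the values given here, no pair of measured compounds differs by this change alone, so the data give no direct guide to its size. Compound 3 carries the same methoxy on its fused ring, yet with a different distal substituent, and gives 4060 nM, a number close to that of compound 1. On that basis the step is expected to be small, with no direction beyond the scatter, and the estimate is a 1.1-fold lower number from compound 1 to compound 4 (0.03 log units; within the scatter). Compound 4 is therefore expected to give about 3200 nM, with a range from 1300 nM to 8000 nM.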

Compound 4, concentration for 50% growth inhibition: 1760 nM
For compound 4 the middle estimate is 1.8-fold (0.26 log units) above the measured one, and the stated range covers the measured number.
By their numbers in this assay, from the lowest: compounds 2, 4, 1 and 3 (each within the scatter of the next, the first and the last beyond it).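

Going by these compounds alone, this is the first reading of the change on its own. With the trimethoxyphenyl substituent and the rest of the shared core kept, methoxy in place of hydrogen on this aromatic carbon, which turns 1,3-benzothiazol-2-yl into 6-methoxy-1,3-benzothiazol-2-yl, gives a 2.0-fold lower number from compound 1 to compound 4 (0.29 log units; within the scatter) in this assay and so cannot be told apart from repeated measurement, though the position evidently takes the added methoxy with no loss of growth inhibition that shows beyond the scatter. Nothing at hand accounts for the size of this step.

What the compounds shown leave open is whether this carbon would read the same with a hydroxyl, an amine or a longer chain such as ethoxy in place of the methoxy. Within the data shown here, it also remains open whether the methoxy would give a similar step with a distal substituent other than trimethoxyphenyl, since only this one pair reads the change directly.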